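Series notes: amine-bearing side chain to bromostyryl substituent

A few compounds are considered here, and "the series" means these few. Any claim that something is new, unique, unknown or untested is made for them only; others in the source may bear on it.

The common core carries a sulfonamide, a benzylthio group and a chlorine, with a five-membered aromatic ring bearing the varied substituent. Among the compounds with values here, compound 1 `CN1CCN(Cc2nnc(-c3cc(S(N)(=O)=O)c(SCc4ccccc4)cc3Cl)o2)CC1` gives 0.308 h in an ADME assay on microsomes from liver (Homo sapiens) for metabolic stability, read by LC-MS, using NADPH, tested at 5 uM (on this read-out higher numbers stand for a longer-lived compound and lower numbers for a shorter-lived compound), the lowest of the three numbers known, though compound 2 `NS(=O)(=O)c1cc(-c2nnc(CN3CCC(Cc4ccccc4)CC3)o2)c(Cl)cc1SCc1ccccc1` at 0.363 h and compound 3 `NS(=O)(=O)c1cc(-c2nnc(CN3CCN(c4ccc(F)cc4)CC3)o2)c(Cl)cc1SCc1ccccc1` at 0.527 h both lie within the scatter of it. Within the data shown here, the single one-place step measured, a 1.7-fold higher number from compound 1 to compound 3 (0.23 log units; within the scatter), exchanges the group on the amine nitrogen of the ring and stays within the scatter.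

Compound 4 `NS(=O)(=O)c1cc(-c2nnc(/C=C/c3ccc(Br)cc3)o2)c(Cl)cc1SCc1ccccc1` differs from compound 1 as follows: 2-(4-bromophenyl)ethenyl in place of (4-methylpiperazin-1-yl)methyl on an aromatic carbon. Among the measured compounds shown here, no measured step bears on this change: the one available step keeps the saturated ring and its two nitrogens in place and only swaps the group on one nitrogen, whereas here that whole ring leaves and an ethenyl-linked aromatic ring with bromine enters. The three measured values spread over a narrow range, so the working expectation is a step of a 1.2-fold lower number from compound 1 to compound 4 (0.09 log units; within the scatter) in this assay, which is expected to stay within the scatter. Compound 4 is therefore estimated at 0.25 h, with a range of 0.1 h to 0.6 h, wide on both sides to reflect the absence of any related measured step.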

Compound 4, half-life: 0.6 h
Estimate against measurement, compound 4: 2.4-fold (0.38 log units) below, within the range that was stated.
By their numbers in this assay, from the lowest: compounds 1, 2, 3 and 4 (each within the scatter of the next).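

In this assay the exchange at this position reads a 1.9-fold higher number from compound 1 to compound 4 (0.29 log units; within the scatter), so on this aromatic carbon of the five-membered aromatic ring with 2 nitrogen and 1 oxygen, (4-methylpiperazin-1-yl)methyl can give way entirely to 2-(4-bromophenyl)ethenyl with no change beyond the scatter. The earlier step swapped only the group on a ring nitrogen, whereas this one removes the saturated ring and its nitrogens altogether and still leaves the half-life within the scatter. Nothing measured here accounts for this result or assigns it to any one part of the exchange.

The change replaces the ring, the linker and the halogen at once, leaving their separate contributions open: a 2-(4-bromophenyl)ethyl group, without the double bond, or a 2-phenylethenyl group, without the bromine, would begin to separate them. As far as these compounds go, it also remains open whether a different kind of group on this carbon, such as a carboxylic acid or a primary amine, would move the half-life beyond the scatter.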